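The source may report more compounds than this note shows. Statements on the series, on what has been measured and on what is new or still open speak of the compounds shown alone.

Measured compounds:
- compound 1, `O=C(CO[N+](=O)[O-])NNC(=O)c1ccc(-n2[nH]c(=O)cc2-c2ccc([N+](=O)[O-])cc2)cc1`: 49.1 ug/mL
- compound 2, `COc1ccccc1-c1cc(=O)[nH]n1-c1ccc(C(=O)NNC(=O)CO[N+](=O)[O-])cc1`: 66.9 ug/mL
- compound 3, `O=C(CO[N+](=O)[O-])NNC(=O)c1ccc(-n2[nH]c(=O)cc2-c2ccccc2O)cc1`: 17.8 ug/mL

All three share one core and differ only in the aryl group attached to the five-membered ring. In a functional assay on aorta (Rattus norvegicus, strain Wistar) for inhibition (on this read-out higher numbers stand for an effect only at larger amounts of compound and lower numbers for an effect already at smaller amounts), compound 3 gives the lowest of the three numbers, with compound 1 giving 49.1 ug/mL and compound 2 giving 66.9 ug/mL.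

Compound 4, `O=C(CO[N+](=O)[O-])NNC(=O)c1ccc(-n2[nH]c(=O)cc2-c2ccc(Cl)cc2)cc1`, has not yet been measured. It differs from compound 3 in one place: 4-chlorophenyl in place of 2-hydroxyphenyl on an aromatic carbon.

Within the data shown here, two measured steps bear on this change. Going to compound 3 from a ring bearing a substituent without a hydrogen-bond donor gave a 2.8-fold lower number from compound 1 to compound 3 (0.44 log units; beyond the scatter). Replacing the methyl with hydrogen on the ring oxygen gave a 3.8-fold lower number from compound 2 to compound 3 (0.58 log units; beyond the scatter), so the hydroxyl appears to go with the lower number. Compound 4 removes that hydroxyl and carries a substituent of the kind seen in compound 1, so the number is expected to rise again, by a modest amount, roughly back toward compound 1.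

For compound 4 the expected step is a 2.5-fold higher number from compound 3 to compound 4 (0.40 log units; beyond the scatter), and the estimated value in this assay is 45 ug/mL, likely between 20 ug/mL and 100 ug/mL.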

Compound 4, half-maximal effective concentration: 21.3 ug/mL
Compound 4: middle estimate off by 2.1-fold (0.32 log units), on the high side; the measured number falls inside the stated range.
By their numbers in this assay, from the lowest: compounds 3 and 4 (each within the scatter of the next); then compounds 1 and 2 (each within the scatter of the next).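

In this assay, putting 4-chlorophenyl in place of 2-hydroxyphenyl leaves the number within the scatter (a 1.2-fold higher number from compound 3 to compound 4 (0.08 log units; within the scatter)), so at this position on the five-membered ring a low number does not depend on the hydroxyl. The earlier link between the hydroxyl and a lower number therefore holds only among compounds 1, 2 and 3, and compound 4 goes against it. The chlorinated ring also stands apart from the other two rings, both for chloro in place of nitro (a 2.3-fold lower number from compound 1 to compound 4 (0.36 log units; beyond the scatter)) and for 4-chlorophenyl in place of 2-methoxyphenyl (a 3.1-fold lower number from compound 2 to compound 4 (0.50 log units; beyond the scatter)), which shows that the group on the ring can shift the number even when no hydroxyl is involved. No measurement here explains why these groups behave as they do.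

Because the substituent's kind and its place on the phenyl ring both change across these compounds, their separate contributions remain unresolved. A plain phenyl group, a 4-hydroxyphenyl group and a 2-chlorophenyl group would help to pull the two apart, and a ring carrying an amine or a carboxylic acid would test a further kind of substituent.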